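Methoxy substitution on the hydroxymethyl-bearing ring of compound 1

The source may hold more compounds than are shown below. What is called first, only, known or untested is meant among the compounds shown, and "the series" means these compounds.

Going by the values given here, compound 1 `Nc1nc(NCc2ccccc2)nc(-c2ccccc2CO)n1` sits at the low end of the three numbers so far: in a functional assay on cells for positive allosteric modulation of G-protein coupled receptor 68 (Homo sapiens), read by a luciferase reporter and cAMP accumulation, with a stated time of 30 min, at pH 6.8 and pH 8.3, in the presence of a further agent that is not named here (on this read-out higher numbers stand for higher potency (the scale is a negative logarithm) and lower numbers for lower potency), compound 1 gives 4.35. Compound 2 `CCNc1nc(NCc2ccccc2)nc(-c2ccccc2CO)n1` gives 4.63 and compound 3 `Nc1nc(NCc2ccccc2)nc(-c2ccc(F)cc2CO)n1` gives 4.58; both differences from compound 1 stay within scatter, so no order among the three can be claimed.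

Compound 4 `COc1cccc(-c2nc(N)nc(NCc3ccccc3)n2)c1CO` differs from compound 1 by methoxy in place of hydrogen on an aromatic carbon, the new group standing ortho to a hydroxymethyl group and meta to a large group, as the structure shows.

Among the compounds with values here, two measured steps bear on this change. Modification of the same ring gave a number 0.23 log units higher from compound 1 to compound 3 (within the scatter), and a change elsewhere on the core gave a number 0.28 log units higher from compound 1 to compound 2 (within the scatter). Within the data shown here, neither moved the read-out beyond scatter, and no methoxy-bearing analogue has been measured, so the expectation is a step of similar size in this assay, at most a slight rise.

Compound 4 is therefore estimated at 4.5, with a range from 4 to 5, an expected step of a number 0.15 log units higher from compound 1 to compound 4 (within the scatter).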

Compound 4, negative logarithm of the antagonist equilibrium constant: 4.16
Estimate against measurement, compound 4: 0.34 log units above; low and high end bracket the measured number.
By their numbers in this assay, from the lowest: compounds 4, 1, 3 and 2 (each within the scatter of the next, the first and the last beyond it).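

A methoxy group on an aromatic carbon, ortho to a hydroxymethyl group and meta to a large group, gives a number 0.19 log units lower from compound 1 to compound 4 (within the scatter) in this assay, so this position accepts the group with no change that can be told from the scatter. Methoxy, fluoro and ethyl, each a single change on compound 1, have now all left the read-out within the scatter, and none of the three marks a position where potency moves. No measurement at hand bears on the reason for this result.

As far as these compounds go, whether ethoxy or a dimethylamino group at this same position would move the read-out beyond the scatter stays open. Also open, from the compounds shown here alone, is whether a carboxylic acid in place of the hydroxymethyl group would do so.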